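Changing the Ether Chain on a Glycine Transporter Inhibitor

A few compounds are considered here, and "the series" means these few. Any claim that something is new, unique, unknown or untested is made for them only; others in the source may bear on it.

Compound 1 `CC(C)Oc1ccc(S(C)(=O)=O)cc1C(=O)N1Cc2cc(C(F)(F)F)cnc2C1` and compound 2 `CC(C)Oc1ccc(S(C)(=O)=O)cc1C(=O)N1Cc2ccc(C3CCOCC3)cc2C1` share much of their structure but differ in their cores; the difference between the two cores is not broken down here. In an assay on CHO cells for inhibition of sodium- and chloride-dependent glycine transporter 1 (Homo sapiens), read by scintillation counting (a lower number here means that less compound is needed, a higher number that more compound is needed for the effect), compound 1 gives 70 nM, while compound 2 gives 28 nM. Compound 3 `CS(=O)(=O)c1ccc(OCCC(F)(F)F)c(C(=O)N2Cc3cc(C(F)(F)F)cnc3C2)c1` is compound 1 with one change, (3,3,3-trifluoropropyl in place of isopropyl on an oxygen on an aromatic ring), and in this assay compound 3 gives 111 nM; the resulting step is a 1.6-fold higher number from compound 1 to compound 3 (0.20 log units; within the scatter). Compound 4 `CS(=O)(=O)c1ccc(OCCC(F)(F)F)c(C(=O)N2Cc3ccc(C4CCOCC4)cc3C2)c1` carries the same change on the core of compound 2, (3,3,3-trifluoropropyl in place of isopropyl on an oxygen on an aromatic ring). Because the step of a 1.6-fold higher number from compound 1 to compound 3 (0.20 log units; within the scatter) stayed within the scatter, a similarly small shift is expected from compound 2 to compound 4 in this assay, namely a 1.6-fold higher number from compound 2 to compound 4 (0.21 log units; within the scatter). Compound 4 is therefore estimated at 45 nM, most likely between 20 nM and 100 nM.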

Compound 4, half-maximal effective concentration in the sodium- and chloride-dependent glycine transporter 1 assay: 137 nM
For compound 4 the middle estimate is 3.0-fold (0.48 log units) below the measured one; the measured number lies above the stated range.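

In the sodium- and chloride-dependent glycine transporter 1 assay compound 4 gives 137 nM and the change on the core of compound 2 gives a 4.9-fold higher number from compound 2 to compound 4 (0.69 log units; beyond the scatter), so the small step seen on the core of compound 1 did not carry over. The two steps differ by more than repeat measurements would explain: the same change on two cores in the sodium- and chloride-dependent glycine transporter 1 assay, a 1.6-fold higher number (0.20 log units; within the scatter) from compound 1 to compound 3 and a 4.9-fold higher number (0.69 log units; beyond the scatter) from compound 2 to compound 4, 3.1-fold (0.49 log units) apart, beyond the scatter of two such steps. This shows that the result of placing 3,3,3-trifluoropropyl in place of isopropyl depends on the core in these two pairs, but it does not show why, and it sets no rule for the series. In a physicochemical assay for solubility (a higher number here means a more soluble compound, a lower number a less soluble compound), compound 2 gives 191 ug/mL and compound 4 gives 334 ug/mL, and these two values lie within the scatter of each other.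

The compounds shown leave open how a plain propyl chain, a longer chain or a chain ending in an amine would behave on this oxygen. They also leave open whether a third core would follow the core of compound 1 or that of compound 2.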